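The source may report more compounds than this note shows. Statements on the series, on what has been measured and on what is new or still open speak of the compounds shown alone.

Measured compounds:
compound 1 `Cc1cc(NCc2ccncc2)n2nc(C)c(-c3ccccc3)c2n1`: 134000 nM
compound 2 `Cc1cc(NCc2ccccn2)n2ncc(-c3ccc(N(C)C)cc3)c2n1`: < 5000 nM

In a physicochemical assay for solubility, read by HPLC, using the shake flask method, measured as kinetic solubility, with a stated time of 2 h, at pH 7.4 (on this read-out higher numbers stand for higher solubility and lower numbers for lower solubility), compound 1 gives 134000 nM. For compound 2 only a limit is known, < 5000 nM, which is a limit of this assay rather than a number; this is the limit of < 5000 nM in this assay, at which 1 of the 2 values shown sits. Going by the values given here, compound 2 therefore stands at the bottom of the two measurements, and compound 1 sits well above it, although no single-change step joins the two.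

Compound 3 `Cc1cc(NCc2ccccn2)n2ncc(-c3cccc(N(C)C)c3)c2n1` differs from compound 2 in one place: 3-(dimethylamino)phenyl in place of 4-(dimethylamino)phenyl on an aromatic carbon. Among the compounds with values here, no measured step of this kind exists among the compounds here, so the size of the change in this assay is open; a step of moderate size in either direction, or none beyond the scatter, is possible. Compound 3 is expected to give about 6000 nM (between 2000 nM and 25000 nM), which means an expected step of an at least 1.2-fold higher number from compound 2 to compound 3 (0.07 log units; that floor lies within the scatter), with a real chance that compound 3 also returns only a limit.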

Compound 3, solubility: 94600 nM
Beside the measured number, compound 3's estimate is 16-fold (1.20 log units) below it, and the stated range ends below it.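

In this assay, exchanging 4-(dimethylamino)phenyl for 3-(dimethylamino)phenyl on this aromatic carbon gives an at least 18-fold higher number from compound 2 to compound 3 (1.27 log units; beyond the scatter). The two compounds hold the same atoms joined differently, so at this place the read-out responds strongly to the arrangement of a group alone, something compound 1 and compound 2 could not show, as they differ in more than one place. The printed size of the step is only a floor, because compound 2 has a limit of the assay and not a number: the limit of < 5000 nM in this assay, at which 1 of the 3 values shown sits.

The compounds shown do not say why this rearrangement changes the read-out so much, as no measurement here separates one cause from another. As far as these compounds go, it also remains open whether a phenyl carrying a morpholine or a carboxylic acid in place of the dimethylamino group would respond in the same way.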